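Swapping the amide for a sulfonamide on the shared core

A few compounds are considered here, and "the series" means these few. Any claim that something is new, unique, unknown or untested is made for them only; others in the source may bear on it.

Three compounds share one core and differ only in the halogen on the ring attached to the carbonyl. In a functional assay on HL-60 cells (Homo sapiens) for antiproliferative activity, read by MTT assay, with a stated time of 72 h (a higher number here means a weaker inhibitor, a lower number a stronger inhibitor), compound 1 `CN(C(=O)c1ccc(F)cc1)c1ccc2[nH]c(-c3n[nH]c4ccccc34)cc2n1` gives 1210 nM, compound 2 `CN(C(=O)c1ccc(Cl)cc1)c1ccc2[nH]c(-c3n[nH]c4ccccc34)cc2n1` gives 450 nM and compound 3 `CN(C(=O)c1ccc(Br)cc1)c1ccc2[nH]c(-c3n[nH]c4ccccc34)cc2n1` gives 1080 nM. Compound 3 sits second highest of these three numbers: its gap to compound 1 is within the scatter, while its gap to compound 2 is beyond it. The measured steps are a 2.7-fold lower number from compound 1 to compound 2 (0.43 log units; beyond the scatter), a 1.1-fold lower number from compound 1 to compound 3 (0.05 log units; within the scatter) and a 2.4-fold higher number from compound 2 to compound 3 (0.38 log units; beyond the scatter).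

Compound 4 `Cc1ccc(S(=O)(=O)N(C)c2ccc3[nH]c(-c4n[nH]c5ccccc45)cc3n2)cc1` changes something else: (4-methylphenyl)sulfonyl in place of (4-bromophenyl)carbonyl on a nitrogen on an aromatic ring. Among the compounds with values here, none of the measured steps touches this part of the molecule, so they say nothing direct about it. They do show that exchanging one halogen for another shifted this assay by at most a modest amount, and that a change of a different kind could go either way. With no guide for direction, the number for compound 4 is expected to stay near that of compound 3, with a wide range, so that the step of a 1.4-fold higher number from compound 3 to compound 4 (0.14 log units; within the scatter) is an estimate only. In this assay compound 4 is therefore estimated at 1500 nM, with a range from 400 nM to 6000 nM.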

Compound 4, half-maximal inhibitory concentration: 3030 nM
For compound 4 the middle estimate is 2.0-fold (0.31 log units) below the measured one; the range from low to high includes it.
By their numbers in this assay, from the lowest: compound 2; then compounds 3 and 1 (each within the scatter of the next); then compound 4.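

In this assay, (4-methylphenyl)sulfonyl in place of the halogen-bearing phenylcarbonyl groups raises the number against all three amides (a 2.8-fold higher number from compound 3 to compound 4 (0.45 log units; beyond the scatter); a 2.5-fold higher number from compound 1 to compound 4 (0.40 log units; beyond the scatter); a 6.7-fold higher number from compound 2 to compound 4 (0.83 log units; beyond the scatter)), which makes compound 4 the weakest of the four, whereas exchanging one halogen for another moved the number both up and down. This single step alters two features together, the carbonyl link becoming a sulfonyl and the halogen on the ring becoming a methyl, and the compounds shown cannot divide the loss between them. No measurement shown here accounts for the weaker result.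

The pairs that would separate the two features are (4-methylphenyl)carbonyl, which keeps the carbonyl and carries the methyl, and (4-bromophenyl)sulfonyl, which keeps the sulfonyl and carries the bromine. Going by these compounds, it also remains open how the number would respond to an amine or a carboxylic acid on that phenyl ring, or to a longer chain in place of the methyl on the nitrogen.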